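Dimethylamino to acetyl at the para position: anticipated cytotoxicity

The compounds below may be only part of what the source reports. "The series", "measured", "known", "first", "only" and "open" are said of these compounds alone.

Compound 1 `COc1cc(C)cc(-c2c(-c3ccnc(-c4ccc(N(C)C)cc4)c3)cnn2CC#N)c1` stands highest of the two numbers in hand: in a functional assay on NCI-H322M cells (Homo sapiens) for cytotoxicity, read by sulforhodamine B assay, with a stated time of 48 h, tested at 0.001 uM (on this read-out lower numbers stand for a stronger effect and higher numbers for a weaker effect at the one concentration tested), compound 1 gives 97%. Compound 2 `Cc1cc(O)cc(-c2nn(CC#N)cc2-c2ccnc(-c3ccc(N(C)C)cc3)c2)c1` sits nearest, and in this assay compound 2 gives 94%, a gap that lies within the scatter, so nothing separates the two. Compound 3 `COc1cc(C)cc(-c2c(-c3ccnc(-c4ccc(C(C)=O)cc4)c3)cnn2CC#N)c1` is not yet measured; it differs from compound 1 by acetyl in place of dimethylamino on an aromatic carbon. For the measured compounds named here, no pair measured so far isolates this kind of exchange, so the step from compound 1 to compound 3 is expected to be none beyond the scatter, as a number 1 percentage points lower from compound 1 to compound 3 (within the scatter). Compound 3 is therefore estimated to give 96%, within 84% to 106%.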

Compound 3, a percentage reported as activity, at one concentration (the size of the read-out at that concentration, not a potency): 102%
Estimate against measurement, compound 3: 6 percentage points below; low and high end bracket the measured number.
By their numbers in this assay, from the lowest: compounds 2, 1 and 3 (each within the scatter of the next).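

In this assay, for the compounds shown here, acetyl in place of dimethylamino on the aromatic carbon gives a number 5 percentage points higher from compound 1 to compound 3 (within the scatter) as the first step that isolates one place. At this single concentration, the exchange therefore separates the two compounds by no more than the scatter, so the read-out does not tell these groups apart at this position. No available evidence bears on this step. Still open, from the compounds shown here alone, is how a carboxylic acid or a piperidine on the same aromatic carbon would read in this assay at this concentration.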